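The source may hold more compounds than are shown below. What is called first, only, known or untested is meant among the compounds shown, and "the series" means these compounds.

The series shares one core, and compound 1 `Cc1ccccc1Cn1cc(COc2ccc3c(=O)ccoc3c2)nn1` and compound 2 `O=c1ccoc2cc(OCc3cn(Cc4ccc(Cl)cc4Cl)nn3)ccc12` differ only in the group on the saturated chain carbon bound to an aromatic nitrogen. In a functional assay on SGC-7901 cells (Homo sapiens) for cytotoxicity, read by MTT assay, with a stated time of 48 h (a lower number here means a stronger inhibitor, a higher number a weaker inhibitor), compound 1 gives no number but a limit of the assay, > 100000 nM. Compound 2 likewise gives only a limit in this assay, > 100000 nM. The step between them, a step that the two limits leave unreadable from compound 1 to compound 2, is therefore unreadable in size and direction. Both values sit at the same limit, (the limit of > 100000 nM in this assay, at which 2 of the 2 values shown sit), so compound 2 stands with no measured number of its own and with no readable step that bears on a further change at this position. Compound 3 `O=c1ccoc2cc(OCc3cn(Cc4cccc([N+](=O)[O-])c4)nn3)ccc12` carries the change (3-nitrophenyl in place of 2,4-dichlorophenyl on a saturated chain carbon bound to an aromatic nitrogen). Going by the values given here, the only measured step at this place, a step that the two limits leave unreadable from compound 1 to compound 2, gives no size to lean on, so nothing points to a shift beyond the scatter in either direction, and the expectation is that compound 3 will again reach only the limit in this assay. The step that the limit leaves unreadable from compound 2 to compound 3 is expected to stay within the scatter. Compound 3 is estimated at 150000 nM, in a range from 50000 nM to 500000 nM.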

Compound 3, half-maximal inhibitory concentration: > 100000 nM
Compound 3 gave a limit, no number; the forecaster's own chance of this, stated with the estimate: 75%; the middle value does not contradict the limit.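

In this assay compound 3 gives only a limit, > 100000 nM. No step can be read between compound 3 and compound 1 or compound 2, because all three stop at the same limit: the limit of > 100000 nM in this assay, at which 3 of the 3 values shown sit. The compounds shown leave open whether any group at this place on the shared core gives a measurable value in this assay.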